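This account rests on a few compounds, and the source may have more. Where it says the series, first, only, none or still open, it means among the compounds named here.

Measured compounds:
Compound 1, `COc1ccc(C(=O)/C=C/c2ccc(-c3ccccc3)cc2)c2c1C=CC(C)(C)O2`, in a functional assay on SK-OV-3 cells (Homo sapiens) for antiproliferative activity, read by MTT assay, with a stated time of 24 h (on this read-out lower numbers stand for stronger inhibition and higher numbers for weaker inhibition), gives > 10000 nM, which is a limit of the assay and not a number.
Compound 2, `COc1ccc(C(=O)/C=C/c2ccc(N3CCCC3)cc2)c2c1C=CC(C)(C)O2`, in this assay gives 7370 nM.

Going by the values given here, compound 2 therefore stands as the only compound of the pair with a number; the other value shown is a limit. For compound 1 there is only (the limit of > 10000 nM in this assay, at which 1 of the 2 values shown sits). Among the compounds with values here, the single measured step runs between these two, and it shows an at least 1.3-fold lower number from compound 1 to compound 2 (0.13 log units; that floor lies within the scatter), a move whose floor lies within the scatter of the measurement.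

Compound 3, `COc1ccc(C(=O)/C=C/c2ccc(-n3ccnc3)cc2)c2c1C=CC(C)(C)O2`, differs from compound 2 in one place: 1H-imidazol-1-yl in place of pyrrolidin-1-yl on an aromatic carbon. Within the data shown here, the only measured step that bears on this change is the one from compound 1 to compound 2, which is small and sits at the edge of the scatter. The entering group is again a five-membered ring with a nitrogen at the point of attachment, so the change is of a similar kind to the one already measured, and no movement beyond the scatter is expected in either direction, with some chance that compound 3 again reaches only a limit. On this basis compound 3 is estimated at 9000 nM, with a range from 4000 nM to 20000 nM, which means an expected step of a 1.2-fold higher number from compound 2 to compound 3 (0.09 log units; within the scatter).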

Compound 3, half-maximal inhibitory concentration: 7200 nM
Compound 3: middle estimate off by 1.3-fold (0.10 log units), on the high side; measured number inside the range.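

In this assay, going by these compounds alone, the step gives the first comparison at this position between two true numbers: a 1.0-fold lower number from compound 2 to compound 3 (0.01 log units; within the scatter). The non-aromatic pyrrolidin-1-yl and the aromatic 1H-imidazol-1-yl, with one and two hetero atoms in their five-membered rings, thus stand within the scatter of each other on this aromatic carbon, para to a large group, so this change of ring type and hetero atom count leaves no measurable mark on the read-out. The comparison with the phenyl compound still gives only a floor, an at least 1.3-fold lower number from compound 1 to compound 3 (0.14 log units; that floor lies within the scatter), and the value of compound 1 is a limit of the assay and not a number: the limit of > 10000 nM in this assay, at which 1 of the 3 values shown sits.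

The compounds shown leave open whether any group at this place can move the number beyond the scatter, as all values so far lie close to or at that limit. On these data alone, an open-chain amine such as dimethylamino, a six-membered ring such as morpholine or a carboxylic acid on the same carbon would test this, and the shared core itself remains unexplored here.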